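Working notes: 4-methylbenzyl on the amide-type nitrogen

A few compounds are considered here, and "the series" means these few. Any claim that something is new, unique, unknown or untested is made for them only; others in the source may bear on it.

Measured in a functional assay on CCRF-CEM cells (Homo sapiens) for inhibition, read by MTT assay, with a stated time of 72 h; a higher number here means a weaker inhibitor, a lower number a stronger inhibitor:
- compound 1 `C=C(Br)C(=O)Nc1cccc(/C=C/C(=O)Nc2cccc(F)c2)c1`: 26000 nM
- compound 2 `C=C(Br)C(=O)Nc1cccc(/C=C/C(=O)Nc2ccc(F)c(F)c2)c1`: 13 nM
- compound 3 `C=C(Br)C(=O)Nc1cccc(/C=C/C(=O)Nc2ccc(C)cc2)c1`: 270 nM

Of the three values, that of compound 3 is the second highest. The other two lie far from it: a 21-fold higher number from compound 2 to compound 3 (1.32 log units; beyond the scatter), and a 96-fold lower number from compound 1 to compound 3 (1.98 log units; beyond the scatter).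

Next is compound 4 `C=C(Br)C(=O)Nc1cccc(/C=C/C(=O)NCc2ccc(C)cc2)c1`, with this change: 4-methylbenzyl in place of 4-methylphenyl on an amide-type nitrogen. In words, 4-methylbenzyl in place of 4-methylphenyl on an amide-type nitrogen.

Going by the values given here, no measured step makes this exchange. The closest evidence comes from changes to the group on that same nitrogen, and all of those steps are large. Even fluoro in place of hydrogen on an aromatic carbon gave a 2000-fold lower number from compound 1 to compound 2 (3.30 log units; beyond the scatter), so a large step in either direction cannot be excluded.

Among the compounds with values here, with no benzyl compound measured, the direction rests on little. Starting from compound 3 at 270 nM, a moderately higher number is expected in this assay, as a 2.2-fold higher number from compound 3 to compound 4 (0.35 log units; beyond the scatter).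

For compound 4 the estimated value is 600 nM, with an expected range of 60 nM to 6000 nM.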

Compound 4, half-maximal inhibitory concentration: 550 nM
For compound 4 the middle estimate is 1.1-fold (0.04 log units) above the measured one; low and high end bracket the measured number.
By their numbers in this assay, from the lowest: compound 2; then compound 3; then compound 4; then compound 1.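

Exchanging 4-methylphenyl for 4-methylbenzyl on the amide-type nitrogen gives the smallest step yet at this position in this assay, with a 2.0-fold higher number from compound 3 to compound 4 (0.31 log units; beyond the scatter), so a benzyl group can stand on this nitrogen with only a modest shift from its phenyl counterpart. Compound 4 nevertheless stays far from both fluorinated compounds, with a 42-fold higher number from compound 2 to compound 4 (1.63 log units; beyond the scatter) and a 47-fold lower number from compound 1 to compound 4 (1.67 log units; beyond the scatter), and it takes a place in the order between compound 3 and compound 1. No supporting data bear on this result.

Open, on these data alone, is whether the same modest step would hold for 3,4-difluorobenzyl, the benzyl counterpart of the 3,4-difluorophenyl group of compound 2. Also open, as far as these compounds go, is how a longer chain such as 2-phenylethyl, or a dimethylamino group on the aromatic ring, would read on this nitrogen.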